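Diaryl ureas on a shared core: an anilino swap

The source may report more compounds than this note shows. Statements on the series, on what has been measured and on what is new or still open speak of the compounds shown alone.

Measured so far:
compound 1, `Cc1ccc(Nc2cc(NC(=O)Nc3c(Cl)cccc3Cl)ncn2)cc1F`, 92%
compound 2, `CCc1cccc(Nc2cc(NC(=O)Nc3cc(OC)cc(OC)c3)ncn2)c1`, 82.1%
compound 3, `COc1cc(Nc2cc(NC(=O)Nc3c(Cl)cccc3Cl)ncn2)cc(C(F)(F)F)c1`, 88.5%

Of the compounds shown here, three sharing one core have been tested in a functional assay on PC-9 cells (Homo sapiens) for inhibition, read by MTT assay, with a stated time of 48 h, tested at 10 uM; a higher number here means more inhibition at the concentration tested (going by the name of the read-out), a lower number less inhibition. Compound 1 gives 92%, compound 3 gives 88.5%, and compound 2 gives 82.1%. The number for compound 2 is the smallest of the three on paper, but the numbers for compound 3 and compound 1 both sit within the usual scatter of it, so the three cannot be told apart.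

Compound 4, `COc1cc(NC(=O)Nc2cc(Nc3ccc(Br)cc3OC)ncn2)cc(OC)c1`, has not yet been measured in this assay . It differs from compound 2 in one place: 4-bromo-2-methoxyphenyl in place of 3-ethylphenyl on a nitrogen on an aromatic ring. Within the data shown here, no step between two measured compounds isolates this kind of change, so there is nothing to lean on beyond the fact that all three measured compounds give high numbers in this assay . The step from compound 2 to compound 4 is therefore expected to be small, in either direction, and not beyond the scatter, with a number 2.9 percentage points higher from compound 2 to compound 4 (within the scatter) as the expected change. Compound 4 is estimated to give 85%, with a range from 70% to 95%.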

Compound 4, a percentage reported as inhibition, at one concentration (the size of the read-out at that concentration, not a potency): 83%
Beside the measured number, compound 4's estimate is 2 percentage points above it; the range from low to high includes it.
By their numbers in this assay, from the lowest: compounds 2, 4, 3 and 1 (each within the scatter of the next).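

In this assay, among these compounds, placing 4-bromo-2-methoxyphenyl in place of 3-ethylphenyl on a nitrogen on an aromatic ring gives a number 0.9 percentage points higher from compound 2 to compound 4 (within the scatter), the first step that isolates a change at this place. Exchanging one substituted phenyl group for a quite differently substituted one, with the rest of compound 2 kept, therefore leaves the read-out indistinguishable from that of the starting compound. No measurement shown offers an explanation for this result.

From the compounds shown here alone, it remains open whether a group of another kind at this nitrogen, such as a carboxylic acid on the phenyl ring or a longer alkyl chain in place of that ring, would keep the number this high. A read-out at one concentration also leaves open whether compound 2 and compound 4 differ in potency.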